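Vinyl for Fluoro on an Indole-Type Core

This account rests on a few compounds, and the source may have more. Where it says the series, first, only, none or still open, it means among the compounds named here.

Measured so far:
Compound 1, `Brc1ccc2ccn(CCN3CCN4CCCCC4C3)c2c1`, gives 70 nM in an assay on HEK293 cells for binding affinity to 5-hydroxytryptamine receptor 7 (Homo sapiens), read by radioligand binding; on this read-out lower numbers stand for stronger inhibition and higher numbers for weaker inhibition.
Compound 2, `CN1CCCN(CCn2ccc3ccc(F)cc32)CC1`, gives 288 nM in this assay.

Of the two numbers in this assay, compound 2 stands at the higher one, which here means weaker binding; compound 1 sits below it by a gap that is beyond the usual scatter of repeated measurements. The two compounds differ in more than one place, so the gap cannot be tied to any single feature.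

Compound 3, `C=Cc1ccc2ccn(CCN3CCCN(C)CC3)c2c1`, keeps the whole of compound 2 apart from one exchange on the aromatic ring: vinyl in place of fluoro on an aromatic carbon. Within the data shown here, nothing among the measured compounds shows what this particular exchange does, so the expectation rests on the value of compound 2 alone and on the fact that the rest of the molecule is unchanged. A step no larger than the scatter, in either direction, seems the most likely outcome, with a wide band of uncertainty.

For compound 3 the estimated value in this assay is 250 nM, with a plausible range from 80 nM to 800 nM. This estimate means a step of a 1.2-fold lower number from compound 2 to compound 3 (0.06 log units; within the scatter), expected to stay within the scatter.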

Compound 3, inhibition constant: 109 nM
Beside the measured number, compound 3's estimate is 2.3-fold (0.36 log units) above it; the measured number falls inside the stated range.
By their numbers in this assay, from the lowest: compounds 1 and 3 (each within the scatter of the next); then compound 2.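

Among these compounds, this is the first change that can be read on its own: in this assay, vinyl in place of fluoro on the same aromatic carbon gives a 2.6-fold lower number from compound 2 to compound 3 (0.42 log units; beyond the scatter), a modest step toward stronger binding with the rest of the molecule unchanged. The position, meta to a fused ring and para to a fused ring, therefore accepts a group of 2 heavy atoms with a double bond where fluoro had 1 heavy atom, and binding does not weaken in this pair. No measurement shown here explains why the number falls, so the step stands as an observation about this one pair of compounds.

As far as these compounds go, it remains open whether the double bond itself matters or whether any small carbon group would do the same here, a question that ethyl, the saturated counterpart of vinyl, or methyl at this position would address. Larger or differently built groups, such as methoxy or a nitrile, are also unexplored on this position, and so is whether the step carries over to the other amine side chain of compound 1.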